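A few compounds are considered here, and "the series" means these few. Any claim that something is new, unique, unknown or untested is made for them only; others in the source may bear on it.

Values so far in a functional assay on the whole organism for inhibition, with Scenedesmus acutus as the target; on this read-out lower numbers stand for stronger inhibition and higher numbers for weaker inhibition

Compound 1 (`O=C(O)c1cc(N2C(=O)C3=C(CCCC3)C2=O)c(F)cc1Cl`) gives 1000 nM
Compound 2 (`CC(C)OC(=O)c1cc(N2C(=O)C3=C(CCCC3)C2=O)c(F)cc1Cl`) gives 13.8 nM
Compound 3 (`CCC(C)OC(=O)c1cc(N2C(=O)C3=C(CCCC3)C2=O)ccc1Cl`) gives 1100 nM

Compound 1 and compound 3 lie within the scatter of each other, and both numbers are far higher than that of compound 2. Compound 4 (`CCC(C)OC(=O)c1cc(N2C(=O)C3=C(CCCC3)C2=O)c(F)cc1Cl`) is compound 3 with a single change, (fluoro in place of hydrogen on an aromatic carbon), which is fluoro in place of hydrogen on an aromatic carbon.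

Among the measured compounds shown here, no measured pair shows this change alone. For the measured compounds named here, the only measured step, a 72-fold lower number from compound 1 to compound 2 (1.86 log units; beyond the scatter), is large, but it concerns the ester end and bears on the fluoro only indirectly: it shows that an ester with the fluoro present can reach low numbers. The closest guide is a comparison of two values. Compound 2, with fluoro and an isopropyl ester, gives 13.8 nM, whereas compound 3, with a sec-butyl ester and no fluoro, gives 1100 nM. These two differ in two places, so this gap cannot be assigned to the fluoro alone. Compound 4 differs from compound 2 only in the ester chain, so a large fall in this assay is expected, and the estimated step is a 44-fold lower number from compound 3 to compound 4 (1.64 log units; beyond the scatter).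

Compound 4 is expected at about 25 nM, with an estimated range from 8 nM to 120 nM.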

Compound 4, half-maximal inhibitory concentration: 60.3 nM
For compound 4 the middle estimate is 2.4-fold (0.38 log units) below the measured one, within the range that was stated.
By their numbers in this assay, from the lowest: compound 2; then compound 4; then compounds 1 and 3 (each within the scatter of the next).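

In this assay, among the compounds shown here, the fluoro, on the aromatic carbon para to a sec-butoxycarbonyl group, brings an 18-fold lower number from compound 3 to compound 4 (1.26 log units; beyond the scatter) as the only change, so this position clearly responds to swapping hydrogen for fluoro. With the fluoro kept in place, the ester end matters as well: the methyl added to the chain gives a 4.4-fold higher number from compound 2 to compound 4 (0.64 log units; beyond the scatter) as a modest loss, while sec-butyl in place of hydrogen on the oxygen gives a 17-fold lower number from compound 1 to compound 4 (1.22 log units; beyond the scatter) as a large gain. This gain from the sec-butyl group is therefore read with the fluoro present, and only for these compounds. Whether a bromo or methoxy group at this position, or a longer chain on the ester, would do as well or better remains open, and the data shown offer no evidence on the reason for the fluoro step.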